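Trimming the Imine Substituent from Ethyl to Methyl

This account rests on a few compounds, and the source may have more. Where it says the series, first, only, none or still open, it means among the compounds named here.

Compound 1 `CC/N=C(/NC#N)NCCCn1nc(C)ccc1=O`: 34.5%
Compound 2 `CC/N=C(\S)NCCCn1nc(-c2ccccc2)ccc1=O`: 39%

In a functional assay on the whole organism with Rattus norvegicus as the target, at a dose of 100 mg/kg (on this read-out lower numbers stand for less inhibition and higher numbers for more inhibition at the one dose given (going by the name of the read-out)), compound 2 gives 39%, the larger of the two numbers recorded, yet its gap to compound 1 lies within the usual scatter, so the two compounds cannot be told apart on this read-out. Compound 3 `C/N=C(\S)NCCCn1nc(-c2ccccc2)ccc1=O` differs from compound 2 by hydrogen in place of methyl on a saturated chain carbon bound to a double-bonded nitrogen. Among the measured compounds shown here, no step between measured compounds exists to calibrate such a change, so no shift beyond the scatter is expected in either direction. Compound 3 is therefore estimated at 37% (range 22% to 52%), an expected step of a number 2 percentage points lower from compound 2 to compound 3 (within the scatter).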

Compound 3, a percentage reported as inhibition, in the whole organism at one dose (the size of the read-out at that dose, not a potency): 38.9%
Compound 3: the middle estimate sits 1.9 percentage points below what was measured; the measured number falls inside the stated range.
By their numbers in this assay, from the lowest: compounds 1, 3 and 2 (each within the scatter of the next).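

In this assay, the change from ethyl to methyl on the double-bonded nitrogen gives a step of a number 0.1 percentage points lower from compound 2 to compound 3 (within the scatter), the first step measured at this position. At this one dose, the read-out therefore does not separate the ethyl and methyl compounds. No measured information is available to explain this result.

The compounds shown leave open whether a longer chain such as propyl, or a primary amine at this position, would move the read-out beyond the scatter. They also leave open whether the same ethyl to methyl change would give a similar step at other doses.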